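Cyclohexyloxy in place of pyridin-3-yl: compound 3

The compounds below may be only part of what the source reports. "The series", "measured", "known", "first", "only" and "open" are said of these compounds alone.

Compound 1 `O=C(CCc1ccc(-c2ccccn2)cc1)N1CCCC1` and compound 2 `O=C(CCc1ccc(-c2cccnc2)cc1)N1CCCC1` share the same core and differ only in the pyridyl group. In an assay on HEK293 cells for inhibition of N-acylethanolamine-hydrolyzing acid amidase (Rattus norvegicus), read by LC-MS, with a stated time of 30 min (a lower number here means a stronger inhibitor, a higher number a weaker inhibitor), compound 1 gives > 100000 nM, which is a limit of the assay and not a number. In this assay compound 2 gives > 100000 nM, again a limit and not a number. The step that the two limits leave unreadable from compound 1 to compound 2 is therefore not readable, as the limit of > 100000 nM in this assay, at which 2 of the 2 values shown sit, shows. Compound 2 thus stands at the limit, with no measured number of its own.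

Compound 3 `O=C(CCc1ccc(OC2CCCCC2)cc1)N1CCCC1` differs from compound 2 by cyclohexyloxy in place of pyridin-3-yl on an aromatic carbon. Within the data shown here, the single measured step concerns another change and is unreadable, so no size for this change can be taken from it, and nothing measured shows whether the new group shifts this assay. Compound 3 is therefore expected to come out at 40000 nM (range 3000 nM to 200000 nM), with a real chance that only a limit is returned. The step of an at least 2.5-fold lower number from compound 2 to compound 3 (0.39 log units; beyond the scatter) is the expectation this implies.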

Compound 3, half-maximal inhibitory concentration: 700 nM
Compound 3: middle estimate off by 57-fold (1.76 log units), on the high side; measured number outside the range, below it.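

Replacing pyridin-3-yl with cyclohexyloxy gives an at least 140-fold lower number from compound 2 to compound 3 (2.15 log units; beyond the scatter), and replacing pyridin-2-yl with cyclohexyloxy gives an at least 140-fold lower number from compound 1 to compound 3 (2.15 log units; beyond the scatter). The group on this aromatic carbon therefore matters in this assay, a point the two pyridyl compounds could not show: with cyclohexyloxy here, the shared core yields a measured number rather than a limit. Both steps are lower bounds only, because compounds 1 and 2 each stand at a limit and not at a number: the limit of > 100000 nM in this assay, at which 2 of the 3 values shown sit.

The change brings in the ether oxygen and the saturated ring together, so the compounds shown do not separate their contributions; a cyclohexyl group attached directly, a phenoxy group or a shorter alkoxy chain would tell them apart. As far as these compounds go, whether the step holds with other changes to the shared core also stays open.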